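Amide substituent variations on the shared core

This account rests on a few compounds, and the source may have more. Where it says the series, first, only, none or still open, it means among the compounds named here.

Compound 3 `CNC(=O)c1ccc(NC(=O)c2cn(Cc3c(F)cccc3F)c3ccc(=O)[nH]c3c2=O)cc1` gives the lowest number of the three measured in an in vitro assay on Sf21 cells for inhibition of high affinity 3',5'-cyclic-AMP phosphodiesterase 7A (Homo sapiens), read by scintillation proximity assay, with a stated time of 30 min (a higher number here means a weaker inhibitor, a lower number a stronger inhibitor), at 29 nM. The nearest measured compound is compound 2 `N#Cc1ccc(NC(=O)c2cn(Cc3c(F)cccc3F)c3ccc(=O)[nH]c3c2=O)cc1`, which gives 96 nM; compound 1 `Nc1ccc(NC(=O)c2cn(Cc3c(F)cccc3F)c3ccc(=O)[nH]c3c2=O)cc1` gives 104 nM. The step of a 3.6-fold lower number from compound 1 to compound 3 (0.55 log units; beyond the scatter) and the step of a 3.3-fold lower number from compound 2 to compound 3 (0.52 log units; beyond the scatter) are both beyond the scatter, while the step of a 1.1-fold lower number from compound 1 to compound 2 (0.03 log units; within the scatter) is within it.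

Compound 4 `O=C(Nc1ccc(C(=O)N2CCOCC2)cc1)c1cn(Cc2c(F)cccc2F)c2ccc(=O)[nH]c2c1=O` differs from compound 3 in one place: morpholin-4-yl in place of methylamino on a carbonyl carbon. Among the compounds with values here, no measured step alters the group on this carbonyl carbon; all three measured steps change the substituent on the aromatic ring instead. The measured steps therefore bear on the change only indirectly, showing that the methylcarbamoyl group is modestly better than amino or cyano, and give no direct guide to the size or direction of the step. The step is expected to stay near the scatter, with a slight lean toward a higher number, so for compound 4 the expected step is a 1.6-fold higher number from compound 3 to compound 4 (0.19 log units; within the scatter). Compound 4 is expected at 45 nM, between 15 nM and 130 nM.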

Compound 4, half-maximal inhibitory concentration: 188 nM
Compound 4: middle estimate off by 4.2-fold (0.62 log units), on the low side; measured number above the stated range.
By their numbers in this assay, from the lowest: compound 3; then compounds 2, 1 and 4 (each within the scatter of the next).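

The carbonyl carbon is itself a sensitive position: morpholin-4-yl in place of methylamino gives a 6.5-fold higher number from compound 3 to compound 4 (0.81 log units; beyond the scatter) in this assay, so a carbonyl on the aromatic carbon does not by itself bring the lower number seen with methylcarbamoyl. The other two steps, a 2.0-fold higher number from compound 2 to compound 4 (0.29 log units; within the scatter) and a 1.8-fold higher number from compound 1 to compound 4 (0.26 log units; within the scatter), are both within the scatter, so (morpholin-4-yl)carbonyl cannot be told apart from cyano or amino on the aromatic carbon. The change removes a hydrogen-bond donor and brings in a six-membered non-aromatic ring, and nothing at hand bears on why the number rises.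

The compounds shown leave open whether the loss of the amide hydrogen or the entry of the ring goes with the higher number. Dimethylamino, ethylamino or piperidin-1-yl on the same carbonyl carbon would bear on this.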